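A few compounds are considered here, and "the series" means these few. Any claim that something is new, unique, unknown or untested is made for them only; others in the source may bear on it.

In a functional assay on NALM-6 cells (Homo sapiens) for cytotoxicity, with a stated time of 72 h (a higher number here means that more compound is needed for the effect, a lower number that less compound is needed), compound 1 `C=C[C@@](C)(/C=C/c1ccc(O)c(CO)c1)CCC=C(C)C` gives a measured 16400 nM. Compound 2 `C=C[C@@](C)(/C=C/c1ccc(O)c(/C=C/C(=O)OCc2ccccc2)c1)CCC=C(C)C` reaches only a limit, > 43400 nM, so it stands without a true number. Compound 3 `C=C[C@@](C)(/C=C/c1ccc(O)c(/C=C(\C)C(=O)OCC)c1)CCC=C(C)C` also gives only a limit, > 7500 nM. Compound 4 `C=C[C@@](C)(/C=C/c1ccc(O)c(/C=C/C=C/c2ccccc2)c1)CCC=C(C)C` keeps the shared core and changes one group: 2-phenylethenyl in place of benzyloxycarbonyl on a double-bonded chain carbon bound to a double-bonded chain carbon. Thus, 2-phenylethenyl stands in place of benzyloxycarbonyl on a double-bonded chain carbon bound to a double-bonded chain carbon. Within the data shown here, the one measured step nearby, a step that the limit leaves unreadable from compound 1 to compound 3, involves a different exchange and offers no usable size. The expected change is therefore only modest, towards a lower number, and another limit is quite possible. The estimated step is an at least 1.4-fold lower number from compound 2 to compound 4 (0.16 log units; that floor lies within the scatter). For compound 4 the expected value is 30000 nM, with an estimated range of 10000 nM to 90000 nM.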

Compound 4, half-maximal effective concentration: > 43400 nM
Compound 4 ended at the assay's limit; the forecaster's own chance of this, stated with the estimate: 50%; at least 1.4-fold (0.16 log units) between middle value and limit.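

No step can be read from compound 2 to compound 4, since both values are limits and not numbers: the limit of > 43400 nM in this assay, at which 2 of the 4 values shown sit. Going by these compounds, whether 2-phenylethenyl or benzyloxycarbonyl needs less compound for the effect remains open.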